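The compounds below may be only part of what the source reports. "The series", "measured", "known", "first", "only" and "open" are said of these compounds alone.

Measured in a functional assay on FM3A cells (Mus musculus) for antiproliferative activity, read by cell counting, with a stated time of 2 days; a higher number here means a weaker inhibitor, a lower number a stronger inhibitor:
- Compound 1 `COc1ccc(C(=O)c2sc(Nc3ccccc3)nc2N)cc1OC`: > 10000 nM, a limit
- Compound 2 `COc1ccc(Nc2nc(N)c(C(=O)c3ccccc3)s2)cc1`: 730 nM
- Compound 3 `Nc1nc(Nc2ccc(Cl)cc2)sc1C(=O)c1ccccc1`: > 10000 nM, a limit

Going by the values given here, compound 2 gives the only actual number in this assay, 730 nM. The other two results both sit at one limit: the limit of > 10000 nM in this assay, at which 2 of the 3 values shown sit.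

Compound 4 `COc1ccc(Nc2nc(N)c(C(=O)c3ccc(Br)cc3)s2)cc1` carries bromo in place of hydrogen on an aromatic carbon, turning phenyl into 4-bromophenyl: bromo in place of hydrogen on an aromatic carbon.

Among the compounds with values here, only one measured step bears on this, and only indirectly: an at least 13-fold higher number from compound 2 to compound 3 (1.13 log units; beyond the scatter). That large step is a different change, made elsewhere in the molecule. It points to a sensitive series, so a moderate move towards a higher number is expected rather than a step of that size.

The expected step is a 2.1-fold higher number from compound 2 to compound 4 (0.31 log units; beyond the scatter).

For compound 4 the estimate is 1500 nM, with an expected range of 300 nM to 8000 nM.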

Compound 4, half-maximal inhibitory concentration: 100 nM
Estimate against measurement, compound 4: 15-fold (1.18 log units) above; the whole stated range lies above it.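

Bromo in place of hydrogen on this phenyl ring, para to a large group, gives a 7.3-fold lower number from compound 2 to compound 4 (0.86 log units; beyond the scatter) in this assay. Going by these compounds alone, the only earlier step, an at least 13-fold higher number from compound 2 to compound 3 (1.13 log units; beyond the scatter), came from chloro in place of methoxy elsewhere in the molecule and ran the opposite way. A halogen is therefore not unfavourable everywhere in this series: compound 4 gains where compound 3 loses.

Going by these compounds, whether this gain is specific to bromo stays open, as a fluoro, a methyl or an amine at this place would show. Much of the series also remains bounded rather than quantified: the limit of > 10000 nM in this assay, at which 2 of the 4 values shown sit.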